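This account rests on a few compounds, and the source may have more. Where it says the series, first, only, none or still open, it means among the compounds named here.

Measured compounds in an ADME assay on PBMC cells (Homo sapiens) for cytotoxicity, with a stated time of 5 days; on this read-out lower numbers stand for stronger inhibition and higher numbers for weaker inhibition:
- Compound 1, `Cc1ccc(C(=O)/C=C/c2ccc(N3CCCCC3)cc2)s1`: 77800 nM
- Compound 2, `O=C(/C=C/c1ccc(N2CCCCC2)cc1)c1ccc(Br)s1`: in this assay compound 2 gives only a limit, > 100000 nM
- Compound 3, `Cc1csc(C2=NNC(c3ccc(N4CCCCC4)cc3)C2)c1`: 24400 nM

Among these, compound 3 gives the lowest of the two numbers reported in this assay; the nearest other number belongs to compound 1, which sits higher, and the gap between the two lies beyond the usual scatter. Compound 2 gives a limit of the assay rather than a number, so its place cannot be fixed more closely than that (the limit of > 100000 nM in this assay, at which 1 of the 3 values shown sits).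

Compound 4, `Brc1ccc(C2=NNC(c3ccc(N4CCCCC4)cc3)C2)s1`, has not yet been measured. It differs from compound 3 in a single place: 5-bromothiophen-2-yl in place of 4-methylthiophen-2-yl on a carbon with a double bond to nitrogen. Among the measured compounds shown here, the one measured step that resembles this change is the swap of bromo for methyl on an aromatic carbon, which gave an at least 1.2-fold higher number from compound 1 to compound 2 (0.10 log units; that floor lies within the scatter), with compound 2 ending at the limit. That step is small and the floor lies within the scatter, yet it points toward a higher number. For the measured compounds named here, the present change also moves the substituent to a different ring position, for which there is no measured step. The expected outcome for compound 4 is a modest rise, a 1.8-fold higher number from compound 3 to compound 4 (0.27 log units; within the scatter), in this assay. The estimate for compound 4 is 45000 nM, within a range from 15000 nM to 110000 nM.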

Compound 4, half-maximal inhibitory concentration: 80000 nM
The estimate for compound 4 lay 1.8-fold (0.25 log units) below the measured number; the range from low to high includes it.
By their numbers in this assay, from the lowest: compound 3; then compounds 1 and 4 (each within the scatter of the next). At a limit, above all of these: compound 2.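

In this assay, putting 5-bromothiophen-2-yl in place of 4-methylthiophen-2-yl on this carbon with a double bond to nitrogen gives a 3.3-fold higher number from compound 3 to compound 4 (0.52 log units; beyond the scatter), so the change clearly weakens the inhibition read out here and is not lost in the scatter. Among the compounds shown here, the earlier swap of bromo for methyl pointed the same way, with an at least 1.2-fold higher number from compound 1 to compound 2 (0.10 log units; that floor lies within the scatter), but that figure is only a floor, so the new pair is the first to put a full size on a change from a methyl-bearing to a bromo-bearing group. Compound 2 gives only a limit of the assay, not a number: the limit of > 100000 nM in this assay, at which 1 of the 4 values shown sits.

The compounds shown leave open how much of the rise belongs to the bromine itself and how much to where it sits on the ring, a question that 5-methylthiophen-2-yl or 4-bromothiophen-2-yl on the same carbon would help to separate. Also open, as far as these compounds go, is how this position would respond to quite different groups, such as a plain phenyl or a ring carrying a carboxylic acid.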